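The source may hold more compounds than are shown below. What is called first, only, known or untested is meant among the compounds shown, and "the series" means these compounds.

Measured so far:
compound 1 `Cc1nc2ccc(NCc3cccc(C(F)(F)F)c3)cc2n(CCNC(=O)[C@@H](C)O)c1=O` — 3900 nM
compound 2 `CC(=O)NCCn1c(=O)c(C)nc2ccc(NCc3cccc(C(F)(F)F)c3)cc21` — 162 nM

In an assay for inhibition of acyl-CoA desaturase 1 (Rattus norvegicus), using microsomes (on this read-out higher numbers stand for weaker inhibition and lower numbers for stronger inhibition), compound 2 holds the lowest of the two numbers, and its nearest neighbour is compound 1, which sits a step of a 24-fold lower number from compound 1 to compound 2 (1.38 log units; beyond the scatter) apart. Within the data shown here, that step, methyl in place of 1-hydroxyethyl on the carbonyl carbon of the side-chain amide, is the only measured comparison in the set and it is large.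

Compound 3 `Cc1nc2ccc(NCc3cccc(C(F)(F)F)c3)cc2n(CCNC(=O)C(O)CO)c1=O` has not yet been measured. It differs from compound 2 by 1,2-dihydroxyethyl in place of methyl on a carbonyl carbon. Among the measured compounds shown here, the only step that bears on this change is the one from compound 1 to compound 2, which runs the other way: removing a single hydroxyl from the carbonyl substituent gave a much lower number. Going from compound 2 to compound 3 reverses that move and adds a second hydroxyl, so a step upward in this assay is expected, of a size at least comparable to a 24-fold lower number from compound 1 to compound 2 (1.38 log units; beyond the scatter). Compound 3 is therefore expected to show a step of a 31-fold higher number from compound 2 to compound 3 (1.49 log units; beyond the scatter) and a value around 5000 nM, with a range from 1500 nM to 15000 nM.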

Compound 3, half-maximal inhibitory concentration: 268 nM
Beside the measured number, compound 3's estimate is 19-fold (1.27 log units) above it, outside the stated range (below it).
By their numbers in this assay, from the lowest: compounds 2 and 3 (each within the scatter of the next); then compound 1.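

In this assay, the carbonyl carbon of the side-chain amide accepts four heavy atoms in place of one: methyl and 1,2-dihydroxyethyl cannot be told apart at this place (a 1.7-fold higher number from compound 2 to compound 3 (0.22 log units; within the scatter)), even with two hydrogen-bond donors and two hydrogen-bond acceptors entering. The large gap seen with 1-hydroxyethyl therefore does not extend to every hydroxyl-bearing substituent here (a 15-fold lower number from compound 1 to compound 3 (1.16 log units; beyond the scatter)), so no single trend with hydroxyl substitution holds, and compound 1 is the compound that goes against any reading of this place as tolerant. No data on the compounds shown account for the gap between the two hydroxyl-bearing substituents.

Going by these compounds, compound 1 is drawn with a defined configuration at the hydroxyl-bearing carbon and compound 3 without one, so what part configuration plays in the gap remains open. Also open, on these data alone, is how hydroxymethyl, aminomethyl, a carboxylic acid or a longer hydroxyalkyl chain on this carbonyl carbon would read against methyl and 1,2-dihydroxyethyl.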